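The source may report more compounds than this note shows. Statements on the series, on what has been measured and on what is new or still open speak of the compounds shown alone.

Measured compounds:
compound 1, `CCCCCCc1ccc(C(=O)/C=C\C(=O)O)cc1`: 17700 nM
compound 2, `C/C=C/C(=O)Nc1ccc(CCCCCC)cc1`: > 100000 nM
compound 3, `C#CC(=O)Oc1ccc(CCCCCC)cc1`: 6200 nM

In an in vitro assay on BL21-DE3 cells for displacement of a labelled ligand from thyroid hormone receptor beta (Homo sapiens), read by fluorescence polarization (a higher number here means a weaker inhibitor, a lower number a stronger inhibitor), compound 3 gives the lower of the two measured numbers, with compound 1 higher by a step beyond the usual scatter. Compound 2 reaches only a limit of this assay, (the limit of > 100000 nM in this assay, at which 1 of the 3 values shown sits), so its number is not known. Compound 4, `CCCCCCc1ccc(C(=O)C2CO2)cc1`, differs from compound 3 in one place: (oxiran-2-yl)carbonyl in place of (ethynylcarbonyl)oxy on an aromatic carbon. Within the data shown here, the one measured step at this position, an at least 16-fold lower number from compound 2 to compound 3 (1.20 log units; beyond the scatter), was large, so the group on this aromatic carbon matters in this assay. Compound 4 is expected to give 12000 nM, between 2500 nM and 60000 nM. The expected step is a 1.9-fold higher number from compound 3 to compound 4 (0.29 log units; within the scatter).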

Compound 4, half-maximal inhibitory concentration in the thyroid hormone receptor beta assay: 19100 nM
Estimate against measurement, compound 4: 1.6-fold (0.20 log units) below, and the stated range covers the measured number.
By their numbers in the thyroid hormone receptor beta assay, from the lowest: compound 3; then compounds 1 and 4 (each within the scatter of the next). At a limit, above all of these: compound 2.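

In the thyroid hormone receptor beta assay, two groups with the same heavy atoms are told apart on this aromatic carbon, a 3.1-fold higher number from compound 3 to compound 4 (0.49 log units; beyond the scatter), whereas oxiran-2-yl and 2-carboxyethenyl on the carbonyl carbon are not, a 1.1-fold higher number from compound 1 to compound 4 (0.03 log units; within the scatter). In the thyroid hormone receptor beta assay compound 2 gives > 100000 nM, which is a limit of the assay. In the thyroid hormone receptor beta assay the step from that limit is therefore only a bound: an at least 5.2-fold lower number from compound 2 to compound 4 (0.71 log units; beyond the scatter). The change that raises the number there also raises it in a physicochemical assay for solubility, in phosphate buffer (on this read-out lower numbers stand for lower solubility and higher numbers for higher solubility), an 11-fold higher number from compound 3 to compound 4 (1.05 log units; beyond the scatter), so the weaker binder here is the more soluble one. In the physicochemical assay compound 3 gives 18000 nM and compound 4 gives 204000 nM.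

Going by these compounds, what an amine on this aromatic carbon would give in either assay remains open.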